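The source may hold more compounds than are shown below. What is called first, only, known or untested is meant among the compounds shown, and "the series" means these compounds.

In a functional assay, with a stated time of 20 min (on this read-out lower numbers stand for stronger inhibition and higher numbers for weaker inhibition), compound 1 `CCOC(=O)c1cnn(-c2nc(-c3cccc(OC)c3OC)c(C#N)c(=O)n2C)c1N` gives 54 ug/mL and compound 2 `CCOC(=O)c1cnn(-c2nc(-c3ccccc3O)c(C#N)c(=O)n2C)c1N` gives 48 ug/mL, so the two lie within the scatter of each other. Compound 3 `CCOC(=O)c1cnn(-c2nc(-c3ccc(Cl)cc3)c(C#N)c(=O)n2C)c1N` departs from compound 2 in one place: 4-chlorophenyl in place of 2-hydroxyphenyl on an aromatic carbon. Going by the values given here, the only measured step that bears on this is a 1.1-fold lower number from compound 1 to compound 2 (0.05 log units; within the scatter), a swap at the same place that stayed within the scatter. Among the compounds with values here, with that single step as a guide, no change beyond the scatter is expected in this assay, although no measured compound carries chlorine. The estimated step is a 1.0-fold higher number from compound 2 to compound 3 (0.02 log units; within the scatter). For compound 3 the expected value is 50 ug/mL, with an estimated range of 20 ug/mL to 120 ug/mL.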

Compound 3, half-maximal inhibitory concentration: 64 ug/mL
Compound 3: middle estimate off by 1.3-fold (0.11 log units), on the low side, and the stated range covers the measured number.
By their numbers in this assay, from the lowest: compounds 2, 1 and 3 (each within the scatter of the next).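

In this assay the position also tolerates a para-chlorinated ring: 4-chlorophenyl gives a 1.3-fold higher number from compound 2 to compound 3 (0.12 log units; within the scatter) and a 1.2-fold higher number from compound 1 to compound 3 (0.07 log units; within the scatter) as well. Compound 3 has no hydrogen-bond donor or acceptor on this ring, unlike compound 2, yet the step stays within the scatter, so among these compounds, those counts on the ring do not separate the numbers. No measurement on hand explains this result. The compounds shown leave open whether an amine, a carboxylic acid or a longer chain at this aromatic carbon, in place of the phenyl ring, would move the number beyond the scatter.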